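Three Close Values and an Untested Four-Membered Ring

This account rests on a few compounds, and the source may have more. Where it says the series, first, only, none or still open, it means among the compounds named here.

- compound 1 `C=CC(=O)NCCOc1ccc(Oc2c(-c3ccc(F)cc3)sc3cc(O)ccc23)cc1` with 23000 nM
- compound 2 `CNC(=O)/C=C/CNCCOc1ccc(Oc2c(-c3ccc(F)cc3)sc3cc(O)ccc23)cc1` with 16100 nM
- compound 3 `C/C=C/C(=O)NCCOc1ccc(Oc2c(-c3ccc(F)cc3)sc3cc(O)ccc23)cc1` with 21700 nM

In a functional assay on MCF7 cells (Homo sapiens) for antiproliferative activity, read by CCK-8 assay, with a stated time of 48 h (on this read-out higher numbers stand for weaker inhibition and lower numbers for stronger inhibition), compound 3 gives 21700 nM and sits within the scatter of both other compounds. Going by the values given here, compound 4 `CN(C)C(=O)/C=C/CN1CC(Oc2ccc(Oc3c(-c4ccc(F)cc4)sc4cc(O)ccc34)cc2)C1` differs from compound 3 by 1-(3-(dimethylcarbamoyl)prop-2-en-1-yl)azetidin-3-yl in place of 2-(((prop-1-en-1-yl)carbonyl)amino)ethyl on an oxygen on an aromatic ring and none of the measured compounds carries the four-membered non-aromatic ring. The measured steps bear on this change only in part, since each alters the end of the chain and keeps the 2-aminoethyl link: a 1.1-fold lower number from compound 1 to compound 3 (0.03 log units; within the scatter) and a 1.4-fold lower number from compound 1 to compound 2 (0.15 log units; within the scatter) and a 1.3-fold higher number from compound 2 to compound 3 (0.13 log units; within the scatter) all stay within the scatter. Compound 2 is the closest comparison, as it carries 3-(methylcarbamoyl)prop-2-en-1-yl on an amine nitrogen, and its value of 16100 nM gives only a weak hint toward a lower number. A modest move in that direction is therefore expected in this assay with no firm expectation of leaving the scatter. The expected step is a 1.7-fold lower number from compound 3 to compound 4 (0.22 log units; within the scatter) and the untested ring keeps this estimate wide. Compound 4 is expected at about 13000 nM with 4000 nM to 30000 nM as its estimated range.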

Compound 4, half-maximal inhibitory concentration: 22300 nM
For compound 4 the middle estimate is 1.7-fold (0.23 log units) below the measured one, and the stated range covers the measured number.
By their numbers in this assay, from the lowest: compounds 2, 3, 4 and 1 (each within the scatter of the next).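

In this assay, going by these compounds alone, the one compound with a four-membered non-aromatic ring on this oxygen stays level with the three open-chain compounds: a 1.0-fold higher number from compound 3 to compound 4 (0.01 log units; within the scatter) and a 1.4-fold higher number from compound 2 to compound 4 (0.14 log units; within the scatter) and a 1.0-fold lower number from compound 1 to compound 4 (0.01 log units; within the scatter) all lie within the scatter. The earlier steps shown here changed only the chain end, whereas this one replaces the whole group on the oxygen, and the four compounds still form a single flat set. No measurement at hand accounts for this flat result.

Since the ring and the chain end change together in compound 4, the share of the ring alone stays unresolved. As far as these compounds go, whether a pyrrolidine or piperidine ring, or a longer chain, on this oxygen would leave this flat set also stays open.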